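Benzyl Ester in Place of Isobutyl: Expected Potency

The compounds below may be only part of what the source reports. "The series", "measured", "known", "first", "only" and "open" are said of these compounds alone.

Of the compounds shown here, two sharing one core have so far been measured in an assay on isolated protein for antagonist activity at Voltage-dependent L-type calcium channel subunit alpha-1C (Cavia porcellus), with a stated time of 15 min; a lower number here means a stronger inhibitor, a higher number a weaker inhibitor. Compound 1, `CC1=C(C(=O)OCc2ccccc2)C(c2csc(-c3ccc(Cl)cc3)n2)C(C(=O)OCc2ccccc2)=C(C)N1`, carries two benzyl esters and in this assay gives 11000 nM. Compound 2, `CCOC(=O)C1=C(C)NC(C)=C(C(=O)OCC(C)C)C1c1csc(-c2ccc(Cl)cc2)n1`, carries an ethyl ester together with an isobutyl ester, and in this assay compound 2 gives 15400 nM. These two numbers lie within the usual scatter of repeated measurements of each other, so neither compound can be called the stronger or the weaker inhibitor on this evidence.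

Compound 3, `CCOC(=O)C1=C(C)NC(C)=C(C(=O)OCc2ccccc2)C1c1csc(-c2ccc(Cl)cc2)n1`, differs from compound 2 in one place: phenyl in place of isopropyl on a saturated chain carbon bound to an oxygen next to a carbonyl group. Going by the values given here, no pair of measured compounds shows exactly this change on its own, but compound 1 already shows that a benzyl ester on this core goes together with a number close to that of compound 2. The step expected a 1.3-fold lower number from compound 2 to compound 3 (0.11 log units; within the scatter) is therefore small, leaning if anything towards a slightly lower number, and not beyond the scatter. Compound 3 is estimated at 12000 nM, with a range from 5000 nM to 30000 nM.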

Compound 3, half-maximal inhibitory concentration: 3290 nM
The estimate for compound 3 lay 3.6-fold (0.56 log units) above the measured number; measured number below the stated range.
By their numbers in this assay, from the lowest: compound 3; then compounds 1 and 2 (each within the scatter of the next).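

This position turns out to be more sensitive than compound 1 alone suggested: with the ethyl ester kept on the other side, isobutyl to benzyl gives a 4.7-fold lower number from compound 2 to compound 3 (0.67 log units; beyond the scatter), so the phenyl of the benzyl ester counts for more than the isopropyl it replaces. The benzyl ester does not lower the number wherever it stands, since replacing the second benzyl ester of compound 1 with an ethyl ester, methyl in place of phenyl, gives a 3.3-fold lower number from compound 1 to compound 3 (0.52 log units; beyond the scatter), and one benzyl ester paired with one ethyl ester therefore beats both neighbours, making compound 3 the strongest inhibitor of the three. Nothing available here explains why either change moves the number as it does.

On these data alone, whether the gain belongs to the phenyl ring itself or to the longer reach of the ester chain remains open, and a phenethyl ester, with a longer chain before the ring, would bear on that. Also open, as far as these compounds go, is how the number would respond to an amine at the end of this ester chain, or to a carboxylic acid in place of the ester.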